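The source may hold more compounds than are shown below. What is called first, only, known or untested is meant among the compounds shown, and "the series" means these compounds.

In a functional assay on MDA-MB-231 cells (Homo sapiens) for cytotoxicity, read by MTT assay, with a stated time of 72 h (a higher number here means a weaker inhibitor, a lower number a stronger inhibitor), compound 1 `Nc1ccccc1NC(=O)c1ccc(NC(=S)NCc2cccc(F)c2)cc1` gives 74000 nM and compound 2 `Nc1ccccc1NC(=O)c1ccc(NC(=S)NCc2cccc(Cl)c2)cc1` gives 92000 nM. The step of a 1.2-fold lower number from compound 2 to compound 1 (0.09 log units; within the scatter) corresponds to fluoro in place of chloro on an aromatic carbon. Compound 3 `Nc1ccccc1NC(=O)c1ccc(NC(=O)NCc2ccc(Cl)nc2)cc1` gives 34000 nM, the lowest of the three numbers; the difference between its core and the core of compound 2 is not broken down here. Compound 4 `Nc1ccccc1NC(=O)c1ccc(NC(=O)NCc2ccc(F)nc2)cc1` has not yet been measured. It differs from compound 3 by fluoro in place of chloro on an aromatic carbon. This is the same kind of change as that from compound 2 to compound 1, but the surroundings differ: in compound 1 the fluoro sits on a six-membered aromatic ring of carbon only, meta to a large group, whereas in compound 4 it sits on a six-membered aromatic ring with 1 nitrogen, next to the ring nitrogen and para to a large group. Because a 1.2-fold lower number from compound 2 to compound 1 (0.09 log units; within the scatter) lay within the scatter, the step of a 1.1-fold lower number from compound 3 to compound 4 (0.05 log units; within the scatter) is expected to be small as well. Compound 4 is therefore estimated at 30000 nM, with a range from 12000 nM to 75000 nM.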

Compound 4, half-maximal inhibitory concentration: 91000 nM
The estimate for compound 4 lay 3.0-fold (0.48 log units) below the measured number; measured number outside the range, above it.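

In this assay, fluoro in place of chloro on the pyridine core gives a 2.7-fold higher number from compound 3 to compound 4 (0.43 log units; beyond the scatter), a modest loss of potency. Set beside the earlier step on the other core, the same change did not carry over with the same size, so the near-neutral result there cannot be assumed to transfer: the same change on two cores in this assay, a 1.2-fold lower number (0.09 log units; within the scatter) from compound 2 to compound 1 and a 2.7-fold higher number (0.43 log units; beyond the scatter) from compound 3 to compound 4, 3.3-fold (0.52 log units) apart, beyond the scatter of two such steps. This rests on a single pair per core, and the difference between the two cores is not broken down, so it does not show which feature of the cores accounts for the gap.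

The compounds shown leave open how a methyl, a nitrile or an amine on that aromatic carbon would compare with the two halogens. They also leave open whether such groups would behave alike on both cores.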